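The source may report more compounds than this note shows. Statements on the series, on what has been measured and on what is new or still open speak of the compounds shown alone.

In a functional assay on DU-145 cells (Homo sapiens) for cytotoxicity, read by MTT assay (on this read-out lower numbers stand for stronger inhibition and higher numbers for weaker inhibition), compound 1 `CC(C)=CC[C@@H](OC[C@H](C)O)C1=CC(=O)c2c(O)ccc(O)c2C1=O` gives 24500 nM and compound 3 `CCCCC(CC(=O)O[C@H](CC=C(C)C)C1=CC(=O)c2c(O)ccc(O)c2C1=O)OC(C)=O` gives 67700 nM, the higher of the two actual numbers. Compound 2 `CC(C)=CC[C@@H](OC(=O)c1ccco1)C1=CC(=O)c2c(O)ccc(O)c2C1=O` reports only a limit, > 100000 nM.

In compound 4 `CC(C)=CC[C@@H](OC(=O)CC(C)(O)C(C)C)C1=CC(=O)c2c(O)ccc(O)c2C1=O`, 1-hydroxy-1,2-dimethylpropyl replaces 1-acetoxypentyl on a saturated chain carbon bound to a carbonyl carbon (1-hydroxy-1,2-dimethylpropyl in place of 1-acetoxypentyl on a saturated chain carbon bound to a carbonyl carbon).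

Among the compounds with values here, two measured steps bear on this change. The first, an at least 4.0-fold higher number from compound 1 to compound 2 (0.61 log units; beyond the scatter), shows that swapping this side group can move the number beyond the scatter. The second, an at least 1.4-fold lower number from compound 2 to compound 3 (0.16 log units; that floor lies within the scatter), has a floor within the scatter. Compound 1, the measured compound with a hydroxyl on its side group, gives 24500 nM.

A small step to a lower number is therefore expected in this assay, an estimated 1.7-fold lower number from compound 3 to compound 4 (0.23 log units; within the scatter), probably within the scatter. The estimate for compound 4 is 40000 nM, with an expected range of 15000 nM to 95000 nM.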

Compound 4, half-maximal inhibitory concentration: 16900 nM
Compound 4: the middle estimate sits 2.4-fold (0.37 log units) above what was measured, and the stated range covers the measured number.
By their numbers in this assay, from the lowest: compounds 4 and 1 (each within the scatter of the next); then compound 3. At a limit, above all of these: compound 2.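

Unlike the earlier steps at this place, the swap of 1-acetoxypentyl for 1-hydroxy-1,2-dimethylpropyl joins two actual numbers, and it lies beyond the scatter: a 4.0-fold lower number from compound 3 to compound 4 (0.60 log units; beyond the scatter) for this change on a saturated chain carbon bound to a carbonyl carbon. The floor in an at least 5.9-fold lower number from compound 2 to compound 4 (0.77 log units; beyond the scatter) rests on a limit, not a number, held by compound 2: the limit of > 100000 nM in this assay, at which 1 of the 4 values shown sits. The change in a 1.4-fold lower number from compound 1 to compound 4 (0.16 log units; within the scatter) stays within the scatter, so these two hydroxyl-bearing side groups read alike.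

The compounds shown cannot separate adding the hydroxyl from losing the acetoxy group. Going by these compounds, how an amine or a carboxylic acid would read at this place remains open.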